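Working notes: methoxy in place of methyl in this series

The compounds below may be only part of what the source reports. "The series", "measured", "known", "first", "only" and "open" are said of these compounds alone.

Measured so far:
compound 1, `CCCCCCNC(=S)N/N=C1\C(=O)Nc2ccc([N+](=O)[O-])cc21`, in a functional assay on the whole organism for inhibition, with Lemna aequinoctialis as the target, tested at 1000 ug/mL; on this read-out higher numbers stand for more inhibition of growth at the one concentration tested and lower numbers for less inhibition of growth: 60%
compound 2, `Cc1ccc(NC(=S)N/N=C2\C(=O)Nc3ccc([N+](=O)[O-])cc32)cc1`, in this assay: 30%

Compound 2 stands lowest of the two numbers; compound 1 lies higher by a number 30 percentage points lower from compound 1 to compound 2 (beyond the scatter), a swap of the whole group on the amide-type nitrogen. Compound 3, `COc1ccc(NC(=S)N/N=C2\C(=O)Nc3ccc([N+](=O)[O-])cc32)cc1`, differs from compound 2 by methoxy in place of methyl on an aromatic carbon. For the measured compounds named here, no measured step touches this group; the only step known, a number 30 percentage points lower from compound 1 to compound 2 (beyond the scatter), concerns a different exchange and does not bear on it. The working expectation is therefore no step beyond the scatter, no change at the digits printed from compound 2 to compound 3 (within the scatter), and compound 3 is estimated at 30%, within 10% to 55%.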

Compound 3, percent growth inhibition at one concentration: 25%
The estimate for compound 3 lay 5 percentage points above the measured number, within the range that was stated.
By their numbers in this assay, from the lowest: compounds 3 and 2 (each within the scatter of the next); then compound 1.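

At the position para to a large group, methoxy in place of methyl gives a number 5 percentage points lower from compound 2 to compound 3 (within the scatter) in this assay, so this first exchange on the aromatic ring separates the two compounds by no more than the scatter. 4-Methoxyphenyl in place of hexyl gives a number 35 percentage points lower from compound 1 to compound 3 (beyond the scatter), so a second aromatic group on the amide-type nitrogen also stands beyond the scatter from the hexyl compound. No measurement on hand bears on the reason for either step.

As far as these compounds go, whether an amine or a carboxylic acid at this ring position would depart from methyl and methoxy remains open. So does the effect of a chain longer than hexyl on the amide-type nitrogen.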